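The source may report more compounds than this note shows. Statements on the series, on what has been measured and on what is new or still open speak of the compounds shown alone.

Working notes on the series. Of the compounds shown here, two have been measured in an ADME assay on HepG2 2.2.15 cells (Homo sapiens) for cytotoxicity, read by neutral red uptake; on this read-out higher numbers stand for lower toxicity in this test and lower numbers for higher toxicity in this test. Compound 1 `O=c1n([C@H]2CO[C@H](CO)O2)ccc2nc(-c3ccc([N+](=O)[O-])cc3)cn12` gives 517000 nM. Compound 2 `O=c1n([C@H]2CO[C@@H](CO)O2)cc(F)c2nc(-c3ccc([N+](=O)[O-])cc3)cn12` gives 1390000 nM and stands highest of the two numbers; the nearest value, that of compound 1, is lower by a margin beyond the usual scatter. Compound 1 and compound 2 differ in two places, so the two values alone do not separate the contribution of either change.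

The next compound, compound 3 `O=c1n([C@H]2CO[C@H](CO)O2)cc(F)c2nc(-c3ccc([N+](=O)[O-])cc3)cn12`, is not yet measured in this assay. Compared with compound 2, (the two compounds have the same atoms and bonds and differ only in configuration as drawn: 1 of 2 stereo elements differ; a stereocentre at a saturated ring carbon is drawn R in compound 2 and S in compound 3). Among the compounds with values here, nothing among the measured pairs isolates such a configurational change, so no step size can be read from the data. The expectation for compound 3 is a step of a 1.5-fold lower number from compound 2 to compound 3 (0.19 log units; within the scatter) that stays within the scatter, in either direction. Compound 3 is accordingly estimated at 900000 nM, with a range from 350000 nM to 2500000 nM.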

Compound 3, half-maximal cytotoxic concentration: 587000 nM
For compound 3 the middle estimate is 1.5-fold (0.19 log units) above the measured one; the range from low to high includes it.
By their numbers in this assay, from the lowest: compounds 1 and 3 (each within the scatter of the next); then compound 2.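

Configuration alone is now seen to matter in this assay: with the stereocentre at a saturated ring carbon drawn S instead of R, the result is a 2.4-fold lower number from compound 2 to compound 3 (0.37 log units; beyond the scatter), a modest step toward higher toxicity in this test. The step can be assigned to that stereocentre alone: the fact that compounds 2 and 3 differ only in the configuration as drawn. Fluoro in place of hydrogen on an aromatic carbon gives a 1.1-fold higher number from compound 1 to compound 3 (0.06 log units; within the scatter), so with the stereocentre drawn S this replacement stays within the scatter, and the gap between the two earlier compounds is no longer a single unresolved difference.

As far as these compounds go, how fluoro in place of hydrogen acts with the stereocentre drawn R stays open. Also open, from the compounds shown here alone, is how this assay would respond to an amine or a carboxylic acid in place of the nitro group.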